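The source may report more compounds than this note shows. Statements on the series, on what has been measured and on what is new or still open speak of the compounds shown alone.

Of the compounds shown here, three with a shared core have been tested in a functional assay on KB cells (Homo sapiens) for antiproliferative activity, read by sulforhodamine B assay, with a stated time of 3 days; on this read-out lower numbers stand for an effect already at smaller amounts and higher numbers for an effect only at larger amounts of compound. For compound 1 `CCC1=C(O)c2c(oc(-c3ccc(CBr)cc3)cc2=O)C(CC)(CC)C1=O` the result is a limit and not a number, > 46.5 uM. Compound 2 `CCC1=C(O)c2c(oc(-c3ccc(O)c(C)c3C)cc2=O)C(CC)(CC)C1=O` gives 6.5 uM, and compound 3 `CCC1=C(O)c2c(oc(-c3cccc(C)c3C)cc2=O)C(CC)(CC)C1=O` gives 3.1 uM, the lower of the two actual numbers.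

The next compound, compound 4 `CCC1=C(O)c2c(oc(-c3cc(C)cc(C)c3)cc2=O)C(CC)(CC)C1=O`, has 3,5-dimethylphenyl in place of 2,3-dimethylphenyl on an aromatic carbon. Going by the values given here, no measured step isolates this kind of change, in which the atoms stay the same but are joined differently. The closest evidence is a 2.1-fold lower number from compound 2 to compound 3 (0.32 log units; beyond the scatter), a modest step that removes a hydroxy group from the dimethylphenyl ring. The larger steps, an at least 7.1-fold lower number from compound 1 to compound 2 (0.85 log units; beyond the scatter) and an at least 15-fold lower number from compound 1 to compound 3 (1.17 log units; beyond the scatter), replace 4-(bromomethyl)phenyl altogether, so they set only a loose outer bound on what changing this group can do.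

A modest change is therefore expected, and its direction is uncertain. The estimated step, leaning slightly upward, is a 1.6-fold higher number from compound 3 to compound 4 (0.21 log units; within the scatter). In this assay the estimate for compound 4 is 5 uM, with an expected range from 1.5 uM to 17 uM.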

Compound 4, concentration for half-maximal effect: 45.5 uM
Beside the measured number, compound 4's estimate is 9.1-fold (0.96 log units) below it, and the stated range ends below it.
By their numbers in this assay, from the lowest: compound 3; then compound 2; then compound 4. At a limit, above all of these: compound 1.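

The same atoms, joined differently, are enough to produce a large change at this position next to the ring oxygen: in this assay, 3,5-dimethylphenyl in place of 2,3-dimethylphenyl on an aromatic carbon gives a 15-fold higher number from compound 3 to compound 4 (1.17 log units; beyond the scatter). Set against the 4-hydroxy-2,3-dimethylphenyl group, the 3,5-dimethylphenyl group also falls behind, with a 7.0-fold higher number from compound 2 to compound 4 (0.85 log units; beyond the scatter). Compound 1 has only a limit and not a number: the limit of > 46.5 uM in this assay, at which 1 of the 4 values shown sits. The step that remains is only a floor, an at least 1.0-fold lower number from compound 1 to compound 4 (0.00 log units; that floor lies within the scatter), and it sets no order between the two.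

Which of the moved methyl groups matters stays open, and a ring with a single methyl group would be needed to separate them. From the compounds shown here alone, how an amine or a carboxylic acid on this phenyl ring would behave in this assay also remains unknown.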